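Isopentyl for isopropyl on a ring nitrogen

This account rests on a few compounds, and the source may have more. Where it says the series, first, only, none or still open, it means among the compounds named here.

Measured in a physicochemical assay for solubility, in phosphate buffer, at pH 6.5; on this read-out higher numbers stand for higher solubility and lower numbers for lower solubility:
- Compound 1 `CN(C)Cc1ccc(NC(=O)Nc2cccnc2Oc2ccccc2C(C)(C)C)c(F)c1`: 160 ug/mL
- Compound 2 `CC(C)(C)c1ccccc1Oc1ncccc1NC(=O)Nc1ccc(OCC2CCN(Cc3ccccc3)CC2)cc1F`: 2 ug/mL
- Compound 3 `CC(C)N1CCC(COc2ccc(NC(=O)Nc3cccnc3Oc3ccccc3C(C)(C)C)c(F)c2)CC1`: 232 ug/mL

Compound 3 shares the top level of these numbers with one other compound, the comparison being a 1.5-fold higher number from compound 1 to compound 3 (0.16 log units; within the scatter). The other comparison is large: a 120-fold higher number from compound 2 to compound 3 (2.06 log units; beyond the scatter). That step is the closest guide, as it alone changes the group on the amine nitrogen in a ring, with isopropyl in place of benzyl.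

Compound 4 `CC(C)CCN1CCC(COc2ccc(NC(=O)Nc3cccnc3Oc3ccccc3C(C)(C)C)c(F)c2)CC1` has isopentyl in place of isopropyl on that same nitrogen (isopentyl in place of isopropyl on an amine nitrogen in a ring). For the measured compounds named here, no measured compound carries isopentyl, and it has no ring, so only part of the large step seen with compound 2 is expected to return, as a moderate fall in this assay. The expected change is a 3.3-fold lower number from compound 3 to compound 4 (0.52 log units; beyond the scatter). For compound 4 the estimated value is 70 ug/mL, within an expected range of 15 ug/mL to 250 ug/mL.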

Compound 4, solubility: 87 ug/mL
Estimate against measurement, compound 4: 1.2-fold (0.09 log units) below; low and high end bracket the measured number.
By their numbers in this assay, from the lowest: compound 2; then compounds 4, 1 and 3 (each within the scatter of the next, the first and the last beyond it).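

Lengthening the open chain on this ring nitrogen from isopropyl to isopentyl costs only a modest amount in this assay, with a 2.7-fold lower number from compound 3 to compound 4 (0.43 log units; beyond the scatter) beyond the scatter. Compound 2 remains far apart from both, and replacing the phenyl of its benzyl group with isobutyl gives a 44-fold higher number from compound 2 to compound 4 (1.64 log units; beyond the scatter) as a large step. The data shown offer no measurement that explains either step. Still open, on these data alone, is how a cyclohexylmethyl group, which keeps a ring but has no aromatic one, would compare on this nitrogen. As far as these compounds go, a hydroxyethyl group or a chain longer than isopentyl is equally open.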